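The source may hold more compounds than are shown below. What is called first, only, known or untested is meant among the compounds shown, and "the series" means these compounds.

Measured compounds:
Compound 1, `COc1ccc(C(=O)c2ccc3c(c2)C=CC(C)(C)O3)c(NC(=O)CO)c1`: 240 nM
Compound 2, `CNCC(=O)Nc1cc(OC)ccc1C(=O)c1ccc2c(c1)C=CC(C)(C)O2`: 970 nM
Compound 3, `COc1ccc(C(=O)c2cc(OC)c(OC)c(OC)c2)c(NC(=O)CO)c1`: 70 nM

Of the compounds shown here, three have been tested in a functional assay on HeLa cells (Homo sapiens) for antiproliferative activity, read by MTT assay, with a stated time of 48 h; on this read-out lower numbers stand for stronger inhibition and higher numbers for weaker inhibition. Compound 1 gives 240 nM in this assay, and compound 2 gives 970 nM. The two share a core and differ in one place: methylamino in place of hydroxy on a saturated chain carbon bound to a carbonyl carbon. That single exchange produced a 4.0-fold higher number from compound 1 to compound 2 (0.61 log units; beyond the scatter), a loss of potency that lies beyond the usual scatter.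

Compound 3 carries a different core. How the core of compound 3 differs from the core of compound 1 is not broken down here; the two differ in more than one place. In this assay compound 3 gives 70 nM, the lowest of the three numbers, and its gap to compound 1 and to compound 2 is beyond the scatter in each case.

Compound 4, `CNCC(=O)Nc1cc(OC)ccc1C(=O)c1cc(OC)c(OC)c(OC)c1`, has not yet been measured. It stands to compound 3 as compound 2 stands to compound 1: methylamino in place of hydroxy on a saturated chain carbon bound to a carbonyl carbon. The place of the change is described in the same words in both pairs, so this is the same change carried onto the core of compound 3. Among the measured compounds shown here, with only one earlier example of it, the expectation rests on that single step. Compound 4 is expected to give 280 nM in this assay, between 120 nM and 650 nM, because the same change gave a 4.0-fold higher number from compound 1 to compound 2 (0.61 log units; beyond the scatter). That estimate means a 4.0-fold higher number from compound 3 to compound 4 (0.60 log units; beyond the scatter), a step of about the same size as before, though whether the new core answers the change in the same way is not known from these data.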

Compound 4, half-maximal inhibitory concentration: 690 nM
Beside the measured number, compound 4's estimate is 2.5-fold (0.39 log units) below it, and the stated range ends below it.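

On the core of compound 3, methylamino in place of hydroxy on a saturated chain carbon bound to a carbonyl carbon gave, in this assay, a 9.9-fold higher number from compound 3 to compound 4 (0.99 log units; beyond the scatter), so the loss of potency seen on the core of compound 1 appears on this second core as well. Set side by side, the two steps point the same way and cannot be told apart in size: the same change on two cores in this assay, a 4.0-fold higher number (0.61 log units; beyond the scatter) from compound 1 to compound 2 and a 9.9-fold higher number (0.99 log units; beyond the scatter) from compound 3 to compound 4, 2.4-fold (0.39 log units) apart, within the scatter of two such steps

Within this small series, then, the change carried over from one core to the other in both direction and, within the scatter, in size, but two cores are only two examples, so this does not show that the step would hold on any further core, and it gives no reason for the loss of potency.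

The compounds shown leave open how an unsubstituted amine, a dimethylamino group or a carboxylic acid in the same place would compare with hydroxy and methylamino on either core. They also leave open whether a longer chain carrying hydroxy or methylamino would follow the same pattern on the two cores.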